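A few compounds are considered here, and "the series" means these few. Any claim that something is new, unique, unknown or untested is made for them only; others in the source may bear on it.

Compound 1 `CCC(C)(C)C(=O)O[C@@H](C[C@@H](C)CO)C1[C@H](O)CC[C@H](C)[C@@H]1CC[C@@H]1C[C@@H](O)CC(=O)O1` is the open-chain member of the series; in an assay with 3-hydroxy-3-methylglutaryl-coenzyme A reductase (Rattus norvegicus) as the target (on this read-out higher numbers stand for weaker inhibition and lower numbers for stronger inhibition), compound 1 gives 2800 nM. Compound 2 `CCC(C)(C)C(=O)O[C@H]1C[C@@H](C)[C@@H](O)[C@@H]2CC[C@H](C)[C@H](CC[C@@H]3C[C@@H](O)CC(=O)O3)C12` carries a free hydroxyl on the shared core, and in this assay compound 2 gives 40.8 nM. Compound 3 `CCC(C)(C)C(=O)O[C@H]1C[C@@H](C)[C@@H](OC(=O)NCc2ccccc2)[C@@H]2CC[C@H](C)[C@H](CC[C@@H]3C[C@@H](O)CC(=O)O3)C12` is the benzyl carbamate of that hydroxyl; in this assay compound 3 gives 5 nM, the lowest number of the three, separated from compound 2 by the step of an 8.2-fold lower number from compound 2 to compound 3 (0.91 log units; beyond the scatter) and from compound 1 by a far wider gap. Compound 4 `CCC(C)(C)C(=O)O[C@H]1C[C@@H](C)[C@@H](OC(=O)N(Cc2ccccc2)Cc2ccccc2)[C@@H]2CC[C@H](C)[C@H](CC[C@@H]3C[C@@H](O)CC(=O)O3)C12` differs from compound 3 in one place: benzyl in place of hydrogen on an amide-type nitrogen. Within the data shown here, no measured step bears directly on a second benzyl on the carbamate nitrogen; the only measured step, an 8.2-fold lower number from compound 2 to compound 3 (0.91 log units; beyond the scatter), concerns the first benzylcarbamoyl and was modest. A number close to that of compound 3, within or near the scatter and with no firm direction, is therefore expected. Compound 4 is estimated at 6 nM in this assay, within 1.5 nM to 25 nM, which is expected to mean a step of a 1.2-fold higher number from compound 3 to compound 4 (0.08 log units; within the scatter).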

Compound 4, half-maximal inhibitory concentration: 16 nM
Compound 4: the middle estimate sits 2.7-fold (0.43 log units) below what was measured, within the range that was stated.
By their numbers in this assay, from the lowest: compound 3; then compound 4; then compound 2; then compound 1.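

Replacing the amide hydrogen of compound 3 with benzyl gives a 3.2-fold higher number from compound 3 to compound 4 (0.51 log units; beyond the scatter) in this assay, so a second benzyl on this nitrogen is tolerated but does not extend the gain seen on forming the carbamate. That earlier step, an 8.2-fold lower number from compound 2 to compound 3 (0.91 log units; beyond the scatter), showed only the effect of adding benzylcarbamoyl to the free hydroxyl, whereas this step shows that the substitution on the nitrogen also changes the read-out, here in the opposite direction. Nothing available bears on why the number rises.

Still open, from the compounds shown here alone, is how a methyl on the carbamate nitrogen in place of the amide hydrogen would compare with the benzyl of compound 4. Among these compounds, a phenethyl group in place of the single benzyl of compound 3 is also open, with 5 nM as the number to compare against.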